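Benzyl Substituent Swap: From Compound 3 to Compound 4

A few compounds are considered here, and "the series" means these few. Any claim that something is new, unique, unknown or untested is made for them only; others in the source may bear on it.

Of the compounds shown here, three sharing one core have been tested in a functional assay on MGC-803 cells (Homo sapiens) for antiproliferative activity, read by MTT assay, with a stated time of 48 h; a lower number here means a stronger inhibitor, a higher number a weaker inhibitor. Compound 1 `COc1cc(N(Cc2ccccc2)C(=O)CSc2nc3ccccc3s2)cc(OC)c1OC` gives 44300 nM. Compound 2 `COc1ccc(CN(C(=O)CSc2nc3ccccc3s2)c2cc(OC)c(OC)c(OC)c2)cc1F` gives 416 nM. Compound 3 `COc1ccc(CN(C(=O)CSc2nc3ccccc3s2)c2cc(OC)c(OC)c(OC)c2)cc1C` gives 6360 nM, which places it second highest of the three, with a 7.0-fold lower number from compound 1 to compound 3 (0.84 log units; beyond the scatter) and a 15-fold higher number from compound 2 to compound 3 (1.18 log units; beyond the scatter).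

The next step leads to compound 4 `COc1cc(N(Cc2ccc(F)cc2)C(=O)CSc2nc3ccccc3s2)cc(OC)c1OC`, where the change is 4-fluorophenyl in place of 4-methoxy-3-methylphenyl on a saturated chain carbon bound to an amide-type nitrogen. Two earlier steps bear on it: a 110-fold lower number from compound 1 to compound 2 (2.03 log units; beyond the scatter) and a 7.0-fold lower number from compound 1 to compound 3 (0.84 log units; beyond the scatter) both show that adding groups to the phenyl of compound 1 lowered the number, while a 15-fold higher number from compound 2 to compound 3 (1.18 log units; beyond the scatter) shows that the choice of group matters a great deal. Compound 4 keeps a fluorine but loses the methoxy present in both compound 2 and compound 3, so its number is expected to lie between those of compound 1 and compound 2, and the step is estimated as a 1.3-fold lower number from compound 3 to compound 4 (0.10 log units; within the scatter). For compound 4 in this assay the estimate is 5000 nM, with a range from 700 nM to 35000 nM.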

Compound 4, half-maximal inhibitory concentration: > 80000 nM
Compound 4: no number, only a limit; the forecaster's own chance of this, stated with the estimate: 5%; at least 16-fold (1.20 log units) between middle value and limit.
By their numbers in this assay, from the lowest: compound 2; then compound 3; then compound 1. At a limit, above all of these: compound 4.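

In this assay compound 4 gives > 80000 nM, which is a limit of the assay and not a number: the limit of > 80000 nM in this assay, at which 1 of the 4 values shown sits. Taking 4-fluorophenyl in place of 4-methoxy-3-methylphenyl gives an at least 12-fold higher number from compound 3 to compound 4 (1.09 log units; beyond the scatter), and taking it in place of 3-fluoro-4-methoxyphenyl gives an at least 190-fold higher number from compound 2 to compound 4 (2.28 log units; beyond the scatter), so a fluoro on this benzyl group does not by itself reproduce the lower numbers seen with the two methoxy-bearing groups. Against the plain phenyl there is an at least 1.8-fold higher number from compound 1 to compound 4 (0.25 log units; that floor lies within the scatter), a floor that does not separate the two, so, unlike the substitutions of the earlier steps, this one shows no lowering of the number.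

The compounds shown leave open whether 4-methoxyphenyl alone, with neither fluoro nor methyl, would give a number as low as that of compound 2. They also do not tell what a hydroxyl, an amine or a carboxylic acid would do in place of the methoxy on this benzyl group.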